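A few compounds are considered here, and "the series" means these few. Any claim that something is new, unique, unknown or untested is made for them only; others in the source may bear on it.

Measured so far in a functional assay on LNCaP cells (Homo sapiens) for antiproliferative activity, read by WST assay, with a stated time of 3 days; on this read-out lower numbers stand for stronger inhibition and higher numbers for weaker inhibition:
Compound 1 `CCCCCCCOc1c(-c2cc(OC)c(OC)c(OC)c2)oc2ccccc2c1=O`: > 50000 nM (a limit)
Compound 2 `CCCCN(CCCC)CCCCOc1c(-c2cc(OC)c(OC)c(OC)c2)oc2ccccc2c1=O`: 7800 nM

Going by the values given here, compound 2, at 7800 nM, holds the only actual number so far. Compound 1 reads > 50000 nM, and this is a limit of the assay rather than a number.

The next compound, compound 3 `CCCCCN(CCCCC)CCCCOc1c(-c2cc(OC)c(OC)c(OC)c2)oc2ccccc2c1=O`, differs from compound 2 at one place: dipentylamino in place of dibutylamino on a saturated chain carbon, four bonds along the chain from an oxygen on an aromatic ring. It carries dipentylamino in place of dibutylamino on a saturated chain carbon, four bonds along the chain from an oxygen on an aromatic ring.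

Among the compounds with values here, one measured step bears on this change, an at least 6.4-fold lower number from compound 1 to compound 2 (0.80 log units; beyond the scatter). For compound 1, that step rests on (the limit of > 50000 nM in this assay, at which 1 of the 2 values shown sits). The step brought in the dibutylamino group in place of propyl, so it shows that this end of the chain can matter in this assay. Within the data shown here, it does not show how the assay responds when the chains on the amine grow longer, since no measured pair varies them. No step beyond the scatter is therefore expected, and no direction is favoured with any confidence. The expected change is a 1.2-fold lower number from compound 2 to compound 3 (0.08 log units; within the scatter). Compound 3 is estimated at 6500 nM. Its expected range for compound 3 runs from 2500 nM to 17000 nM.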

Compound 3, half-maximal inhibitory concentration: 9700 nM
The estimate for compound 3 lay 1.5-fold (0.17 log units) below the measured number; low and high end bracket the measured number.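

In this assay, going from dibutylamino to dipentylamino gives a 1.2-fold higher number from compound 2 to compound 3 (0.09 log units; within the scatter), so this pair, the only one shown that varies the chains on the amine, shows no measurable response to that change. Dipentylamino in place of propyl gives an at least 5.1-fold lower number from compound 1 to compound 3 (0.71 log units; beyond the scatter), so the gain first seen with dibutylamino is not confined to that one amine, and it holds for both amines shown at this place on the chain. The true size of that gain stays unknown, since the value of compound 1 is a limit and not a number: the limit of > 50000 nM in this assay, at which 1 of the 3 values shown sits.

Only two amines with open chains are shown, so it remains open whether shorter chains, as in dimethylamino, or an amine held in a ring, such as piperidine or morpholine, would read the same or differ beyond the scatter. As far as these compounds go, it is also open how the numbers would respond to a shorter or longer chain between the ring oxygen and the amine, or to a carboxylic acid in place of the amine at the end of that chain.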